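Replacing the oxetanyl amide with a difluoromethylpiperidine amide

The source may hold more compounds than are shown below. What is called first, only, known or untested is meant among the compounds shown, and "the series" means these compounds.

Three compounds share a core and differ at the amide and sulfonyl ends. Compound 2 `CCN(CC)S(=O)(=O)c1ccc(S(=O)(=O)N2CCC[C@@H](C(=O)NC3COC3)C2)cc1` gives 13800 nM in a functional assay on BXPC-3 cells (Homo sapiens) for inhibition, read by MTT assay, with a stated time of 7 days (a lower number here means a stronger inhibitor, a higher number a weaker inhibitor), the highest of the three numbers. Compound 1 `CCN(CC)S(=O)(=O)c1ccc(S(=O)(=O)N2CCC[C@@H](C(=O)N3CCC(O)CC3)C2)cc1` gives 4710 nM, and the step of a 2.9-fold higher number from compound 1 to compound 2 (0.47 log units; beyond the scatter) bears directly on the change at hand. Compound 3 `CC(C)S(=O)(=O)c1ccc(S(=O)(=O)N2CCC[C@@H](C(=O)N3CCC(F)(F)CC3)C2)cc1` gives 50 nM, but it also carries a different sulfonyl group, so only its value is shown here. Compound 4 `CCN(CC)S(=O)(=O)c1ccc(S(=O)(=O)N2CCC[C@@H](C(=O)N3CCC(C(F)F)CC3)C2)cc1` differs from compound 2 in one place: 4-(difluoromethyl)piperidin-1-yl in place of (oxetan-3-yl)amino on a carbonyl carbon. Since the move from a piperidine amide to the oxetanylamino gave a higher number, the reverse is expected to lower it; the expected step is a 12-fold lower number from compound 2 to compound 4 (1.06 log units; beyond the scatter). Compound 4 is therefore estimated at 1200 nM, within 250 nM to 6000 nM.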

Compound 4, half-maximal inhibitory concentration: 450 nM
Estimate against measurement, compound 4: 2.7-fold (0.43 log units) above, within the range that was stated.
By their numbers in this assay, from the lowest: compound 3; then compound 4; then compound 1; then compound 2.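

In this assay, the change on the carbonyl carbon gives a 31-fold lower number from compound 2 to compound 4 (1.49 log units; beyond the scatter) and so reaches well beyond what compound 1 had shown for a piperidine amide. Difluoromethyl in place of hydroxy on a saturated ring carbon gives a 10-fold lower number from compound 1 to compound 4 (1.02 log units; beyond the scatter), so the substituent on the piperidine also matters, not only the presence of that ring. No evidence shown explains either step. From the compounds shown here alone, whether a methyl or trifluoromethyl group on that ring carbon would serve equally remains open. Going by these compounds, the contribution of the sulfonyl end also remains open, since compound 3 differs from compound 4 in more than one place.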